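A few compounds are considered here, and "the series" means these few. Any claim that something is new, unique, unknown or untested is made for them only; others in the source may bear on it.

In a functional assay on KM12 cells (Homo sapiens) for inhibition, read by sulforhodamine B assay, with a stated time of 48 h, tested at 1 uM (a lower number here means a stronger effect, a higher number a weaker effect of the compound at the concentration tested), compound 2 `COc1cc(Cl)cc(-c2nn(-c3cccc(NC(=O)Nc4cccc(C(F)(F)F)c4)c3)cc2-c2ccncc2)c1` gives 38%, the lowest of the two numbers shown. Its nearest neighbour is compound 1 `COc1cc(Cl)cc(-c2nn(-c3cccc(NC(=O)Nc4ccc(Cl)c(Cl)c4)c3)cc2-c2ccncc2)c1`, which in this assay gives 72%. Among the measured compounds shown here, the only measured step, a number 34 percentage points lower from compound 1 to compound 2 (beyond the scatter), covers the exchange of one aromatic group for another on the amide-type nitrogen and was large.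

Compound 3 `COc1cc(Cl)cc(-c2nn(-c3cccc(NC(=O)c4cccc(C(F)(F)F)c4)c3)cc2-c2ccncc2)c1` has not yet been measured. It differs from compound 2 by 3-(trifluoromethyl)phenyl in place of (3-(trifluoromethyl)phenyl)amino on a carbonyl carbon, so the amide-type nitrogen is kept but the group on the carbonyl carbon is no longer bound through an amino link. For the measured compounds named here, none of the measured steps removes an amino group in this way; the step from compound 1 to compound 2 changes only the aromatic group and therefore does not bear on the change from compound 2 to compound 3. Without a comparable step, the size and direction of the change cannot be anchored, and a wide range is the honest expectation. Compound 3 is therefore expected to give 52%, between 25% and 80%, and the step from compound 2 is expected to be a number 14 percentage points higher from compound 2 to compound 3 (beyond the scatter).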

Compound 3, a percentage reported as activity, at one concentration (the size of the read-out at that concentration, not a potency): 56%
Beside the measured number, compound 3's estimate is 4 percentage points below it; low and high end bracket the measured number.
By their numbers in this assay, from the lowest: compound 2; then compound 3; then compound 1.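

Exchanging (3-(trifluoromethyl)phenyl)amino for 3-(trifluoromethyl)phenyl on the carbonyl carbon in this assay gives a number 18 percentage points higher from compound 2 to compound 3 (beyond the scatter), which shows that the amino link counts here as well as the aromatic group, since the 3-(trifluoromethyl)phenyl ring is present in both compounds and the effect still weakens. The same kind of exchange, now also changing the aromatic group, gives a number 16 percentage points lower from compound 1 to compound 3 (beyond the scatter), so the compound without the amino link still outdoes the one carrying (3,4-dichlorophenyl)amino, and the choice of aromatic group can outweigh the loss of that link. No measurement shown here explains why the amino link or the aromatic group matters in this way.

The compounds shown leave open whether the amino link matters through its hydrogen or through the added atom itself, which a methylamino group, a methylene group or an ether oxygen in the same place would test. They also leave open whether a 3,4-dichlorophenyl group bound directly to the carbonyl carbon would respond to the loss of the amino link as the 3-(trifluoromethyl)phenyl group does.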